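The compounds below may be only part of what the source reports. "The series", "measured", "known", "first", "only" and "open" are said of these compounds alone.

Compound 1 `NS(=O)(=O)c1ccc(N2N=C(c3ccc(F)cc3)CC2c2cn(-c3ccccc3)nc2-c2ccccc2)cc1` and compound 2 `COc1ccc(C2=NN(c3ccc(S(N)(=O)=O)cc3)C(c3cn(-c4ccccc4)nc3-c3ccccc3)C2)cc1` share the same core and were both tested in an ADME assay on Vero cells (Chlorocebus sabaeus) for cytotoxicity, read by MTT assay, with a stated time of 72 h; on this read-out lower numbers stand for higher toxicity in this test and higher numbers for lower toxicity in this test. For compound 1 the measurement reaches only the limit of the assay, > 807000 nM. Compound 2 gives 40200 nM in this assay. For the measured compounds named here, the one measured step, an at least 20-fold lower number from compound 1 to compound 2 (1.30 log units; beyond the scatter), therefore starts from a limit, as the limit of > 807000 nM in this assay, at which 1 of the 2 values shown sits, records. Compound 3 `NS(=O)(=O)c1ccc(N2N=C(c3ccc(F)cc3)CC2c2cn(-c3ccccc3)nc2-c2ccc(F)cc2)cc1` differs from compound 1 by fluoro in place of hydrogen on an aromatic carbon. No measured step concerns this change: the one step shown is a different change, methoxy in place of fluoro, and its size says nothing about fluoro in place of hydrogen. For compound 3 the expected step is an at least 1.3-fold lower number from compound 1 to compound 3 (0.12 log units; that floor lies within the scatter), with no change beyond the scatter anticipated. Compound 3 is therefore estimated at 600000 nM, between 150000 nM and 1000000 nM, in this assay, most likely again reported only as a limit.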

Compound 3, half-maximal cytotoxic concentration: > 753000 nM
Compound 3: only a limit was reported; the forecaster's own chance of this, stated with the estimate: 60%; middle value at least 1.2-fold (0.09 log units) from the limit.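

For the compounds shown here, compound 1 and compound 3 are both recorded only as limits in this assay, so no step between them can be read. From the compounds shown here alone, whether fluoro in place of hydrogen on an aromatic carbon changes the half-maximal cytotoxic concentration at all remains open.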